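This account rests on a few compounds, and the source may have more. Where it says the series, first, only, none or still open, it means among the compounds named here.

Within the data shown here, in a functional assay on L02 cells (Homo sapiens) for inhibition, read by Griess assay, with stated times of 1 h and 24 h (on this read-out higher numbers stand for weaker inhibition and lower numbers for stronger inhibition), compound 1 `CCCc1nn(C)c2c(NC(C)C)nc(CCc3cccnc3)nc12` gives 514000 nM, the only true number available so far. Compound 2 `CNc1nc(/C=C/c2ccccc2)nc2ccsc12` reads > 1000000 nM. That value is a limit and not a number.

Compound 3 `Brc1ccc(Nc2nc(/C=C/c3ccccc3)nc3ccsc23)cc1` keeps the core of compound 2 and changes one group: 4-bromophenyl in place of methyl on a nitrogen on an aromatic ring. Put simply, 4-bromophenyl sits in place of methyl on a nitrogen on an aromatic ring, so methylamino becomes (4-bromophenyl)amino. Among the measured compounds shown here, this is a large swap in size, and no pair of measured compounds shows what a change of this kind does in this assay.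

The expectation is therefore loose. A moderate move toward stronger inhibition seems likely, though compound 3 may also stay out of reach of a number, as compound 2 does. For the measured compounds named here, compound 1 at 514000 nM is the one guide to where a measurable value might fall. The expected change is an at least 3.3-fold lower number from compound 2 to compound 3 (0.52 log units; beyond the scatter). For compound 3 the estimate is 300000 nM, with an expected range from 60000 nM to 1000000 nM.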

Compound 3, half-maximal inhibitory concentration: > 1000000 nM
Compound 3 ended at the assay's limit (the forecaster's own chance of this, stated with the estimate: 35%); at least 3.3-fold (0.52 log units) between middle value and limit.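

In this assay compound 3 reads > 1000000 nM, which is a limit and not a number. Compound 2 sits at the same limit, so no step can be read between compound 2 and compound 3: the limit of > 1000000 nM in this assay, at which 2 of the 3 values shown sit. The compounds shown leave open whether 4-bromophenyl in place of methyl changes inhibition at all, and in which direction.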